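The compounds below may be only part of what the source reports. "The series", "measured", "known", "first", "only" and "open" are said of these compounds alone.

In a functional assay on Jurkat cells (Homo sapiens) (on this read-out lower numbers stand for stronger inhibition and higher numbers for weaker inhibition), compound 1 `CC(=O)Nc1cccc(OCC(=O)[C@H](CC(=O)O)NC(=O)[C@@H](NC(=O)COc2cccc3ccccc23)C(C)C)c1` gives > 100000 nM, which is a limit of the assay and not a number. Compound 2 `CC(C)[C@H](NC(=O)COc1cccc2ccccc12)C(=O)N[C@@H](CC(=O)O)C(=O)COc1c(F)ccc(F)c1F` gives 1200 nM, and compound 3 `CC(C)[C@H](NC(=O)COc1cccc2ccccc12)C(=O)N[C@@H](CC(=O)O)C(=O)COc1ccc(F)c(F)c1F` gives 35800 nM, the higher of the two actual numbers. Its nearest neighbour is compound 2, and the gap is a 30-fold higher number from compound 2 to compound 3 (1.47 log units; beyond the scatter). Compound 4 `CC(C)[C@H](NC(=O)COc1cccc2ccccc12)C(=O)N[C@@H](CC(=O)O)C(=O)COc1cccc(C(F)(F)F)c1F` keeps the shared core and differs from compound 3 only in the group on the oxygen: 2-fluoro-3-(trifluoromethyl)phenyl in place of 2,3,4-trifluorophenyl on an oxygen on a saturated carbon. Here 2-fluoro-3-(trifluoromethyl)phenyl takes the place of 2,3,4-trifluorophenyl. For the measured compounds named here, three measured steps touch this same place. Two of them start from the limit, and these are an at least 83-fold lower number from compound 1 to compound 2 (1.92 log units; beyond the scatter) and an at least 2.7-fold lower number from compound 1 to compound 3 (0.44 log units; beyond the scatter). The closest parallel is the large step between the two fluorinated groups, a 30-fold higher number from compound 2 to compound 3 (1.47 log units; beyond the scatter), so in this small set a change among fluorinated phenyl groups alone has moved the number strongly. Because compound 3 stands at 35800 nM and compound 2 at 1200 nM, a moderate drop is expected rather than a rise, with wide uncertainty. The expected change in this assay is a 3.6-fold lower number from compound 3 to compound 4 (0.55 log units; beyond the scatter). For compound 4 the estimate is 10000 nM, with an expected range from 1500 nM to 60000 nM.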

Compound 4, half-maximal inhibitory concentration: 50400 nM
For compound 4 the middle estimate is 5.0-fold (0.70 log units) below the measured one; the measured number falls inside the stated range.
By their numbers in this assay, from the lowest: compound 2; then compounds 3 and 4 (each within the scatter of the next). At a limit, above all of these: compound 1.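

In this assay, 2-fluoro-3-(trifluoromethyl)phenyl and 2,3,4-trifluorophenyl on this oxygen cannot be told apart (a 1.4-fold higher number from compound 3 to compound 4 (0.15 log units; within the scatter)), so the change from 9 to 11 heavy atoms, with a trifluoromethyl group entering, leaves no readable effect here. Compound 2 now stands apart from two other fluorinated groups rather than one (a 42-fold higher number from compound 2 to compound 4 (1.62 log units; beyond the scatter)), which shows that the large gap first seen with compound 3 is not a feature of that one group, and that among the three fluorinated phenyl groups shown only 2,3,6-trifluorophenyl gives a low number. Compound 1 stands at a limit of the assay, not a number, so its step to compound 4 cannot be read (an at least 1.9-fold lower number from compound 1 to compound 4 (0.29 log units; that floor lies within the scatter)): the limit of > 100000 nM in this assay, at which 1 of the 4 values shown sits.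

As far as these compounds go, whether a plain phenyl group or a pentafluorophenyl group on the same oxygen would fall with compound 2 or with compounds 3 and 4 remains open. It also remains open whether the advantage of 2,3,6-trifluorophenyl would persist on a changed core, since all four compounds shown share one.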